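Swapping 4-fluorophenyl for naphthalen-2-yl in compound 2

The compounds below may be only part of what the source reports. "The series", "measured", "known", "first", "only" and "open" are said of these compounds alone.

Measured in a functional assay on PC-3 cells (Homo sapiens) for inhibition, read by MTT assay, with a stated time of 48 h; on this read-out higher numbers stand for weaker inhibition and lower numbers for stronger inhibition:
- Compound 1 `C[C@H]1CCC/C=C/[C@H]2CC[C@H](O)[C@@H](CC(=O)O1)O2`: "not determined" (no result reported)
- Compound 2 `COc1ccc(CO[C@H]2C=C[C@H]3C/C=C\C[C@H](c4ccc(F)cc4)OC(=O)C[C@@H]2O3)cc1`: 2230 nM
- Compound 3 `CCO[C@H]1C=C[C@H]2C/C=C\C[C@H](c3ccc(OC)cc3)OC(=O)C[C@@H]1O2`: 56000 nM

Compound 2 has the lower of the two numbers, so it is the stronger inhibitor, and its gap to compound 3 lies beyond the usual scatter. Compound 4 `COc1ccc(CO[C@H]2C=C[C@H]3C/C=C\C[C@H](c4ccc5ccccc5c4)OC(=O)C[C@@H]2O3)cc1` carries naphthalen-2-yl in place of 4-fluorophenyl on a saturated ring carbon. Within the data shown here, no measured pair differs in one place only, so the data give no direct guide to this swap. In this assay, no step beyond the scatter is therefore expected, in either direction. The estimated step of a 1.3-fold higher number from compound 2 to compound 4 (0.10 log units; within the scatter) is small. For compound 4 the expected value is 2800 nM, with an estimated range from 700 nM to 11000 nM.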

Compound 4, half-maximal inhibitory concentration: 45400 nM
Estimate against measurement, compound 4: 16-fold (1.21 log units) below, outside the stated range (above it).
By their numbers in this assay, from the lowest: compound 2; then compounds 4 and 3 (each within the scatter of the next).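

In this assay, among these compounds, the swap of 4-fluorophenyl for naphthalen-2-yl on this saturated ring carbon gives a 20-fold higher number from compound 2 to compound 4 (1.31 log units; beyond the scatter), a direct reading that the earlier compounds could not provide. This position is therefore not indifferent to its aromatic group: here, two aromatic rings without fluorine give much weaker inhibition than one ring bearing fluorine. Nothing measured here explains the loss. Going by these compounds, the second ring and the loss of fluorine arrive together, so their separate contributions remain open. A plain phenyl or a 4-aminophenyl group at this carbon could begin to separate them.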